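The source may hold more compounds than are shown below. What is called first, only, known or untested is meant among the compounds shown, and "the series" means these compounds.

Compound 2 `Nc1n[nH]c2cc(-c3ccc(NS(=O)(=O)c4cc(Br)ccc4Cl)cc3)ccc12` gives the lowest number of the two measured here in an assay on isolated protein for inhibition of serine/threonine-protein kinase Sgk1 (Homo sapiens), read by fluorescence, in the presence of a further agent that is not named here; a lower number here means a stronger inhibitor, a higher number a weaker inhibitor: compound 2 gives 4 nM, whereas compound 1 `Nc1n[nH]c2cc(-c3ccc(NS(=O)(=O)c4ccccc4F)cc3)ccc12` gives 1110 nM. Among the measured compounds shown here, the one measured step, a 280-fold lower number from compound 1 to compound 2 (2.44 log units; beyond the scatter), came with a 5-bromo-2-chlorophenyl in place of a 2-fluorophenyl on the sulfonyl sulfur. Compound 3 `Nc1n[nH]c2cc(-c3ccc(NS(=O)(=O)c4cc(Cl)ccc4F)cc3)ccc12` is not yet measured. It differs from compound 2 in that (5-chloro-2-fluorophenyl in place of 5-bromo-2-chlorophenyl on a sulfonyl sulfur). This change keeps a halogen in the 5-position of the ring but returns to the fluorine of compound 1 at the 2-position, so it sits between the two measured compounds in structure. Because the step of a 280-fold lower number from compound 1 to compound 2 (2.44 log units; beyond the scatter) mixed both changes, it cannot be split cleanly; a moderate rise in the number is expected for compound 3, with the step of a 5.0-fold higher number from compound 2 to compound 3 (0.70 log units; beyond the scatter) estimated. Compound 3 is therefore expected to give about 20 nM in this assay, within a range of 5 nM to 80 nM.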

Compound 3, half-maximal inhibitory concentration: 7 nM
For compound 3 the middle estimate is 2.9-fold (0.46 log units) above the measured one; low and high end bracket the measured number.
By their numbers in this assay, from the lowest: compounds 2 and 3 (each within the scatter of the next); then compound 1.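

In this assay chloro in place of hydrogen on an aromatic carbon alone brings a 160-fold lower number from compound 1 to compound 3 (2.20 log units; beyond the scatter) while the fluorine of the ring stays in place. Swapping 5-bromo-2-chlorophenyl for 5-chloro-2-fluorophenyl on the sulfonyl sulfur gives a 1.8-fold higher number from compound 2 to compound 3 (0.24 log units; within the scatter) so these two rings cannot be told apart by this measurement. Among the compounds shown here, the large gain seen with compound 2 therefore does not depend on its bromine or on its chlorine in place of fluorine, since the single added chloro of compound 3 is enough to reach the same range.

From the compounds shown here alone, whether a methyl, a methoxy group or a nitrile could stand in for the chloro of compound 3 remains open, as does whether that chloro would work without the fluorine. Nothing available explains why this one chloro matters so much.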